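The source may report more compounds than this note shows. Statements on the series, on what has been measured and on what is new or still open speak of the compounds shown alone.

The measured compounds so far:

compound 1 `Cc1ccc2nc(NC(=O)/C=C/c3ccc(O)cc3)sc2c1`: in a functional assay on the whole organism (Hindlimb, strain albino) with Mus musculus as the target, in the maximal electroshock model, with a stated time of 0.5 h (a higher number here means that more compound is needed for the effect, a lower number that less compound is needed), compound 1 gives 271 umol/kg
compound 2 `O=C(/C=C/c1ccc(O)cc1)Nc1nc2ccccc2s1`: compound 2 gives 517 umol/kg
compound 3 `CC(=O)N1N=C(Nc2nc3ccc(C)cc3s2)CC1OC1=CC=C1`: compound 3 gives 160 umol/kg

Compound 1 and compound 2 share a core and differ in one place: hydrogen in place of methyl on an aromatic carbon. This change made the step of a 1.9-fold higher number from compound 1 to compound 2 (0.28 log units; within the scatter), a step that lies within the scatter, so the two numbers cannot be told apart with confidence.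

Compound 3 has a different core; how its core differs from that of compound 1 is not broken down here. Among the three measured compounds, compound 3 gives the lowest number, with compound 1 within the scatter of it and compound 2 beyond it.

Compound 4 `CC(=O)N1N=C(Nc2nc3ccccc3s2)CC1OC1=CC=C1` has not been measured. It differs from compound 3 in one place: hydrogen in place of methyl on an aromatic carbon. Among the compounds with values here, this is the same change as the one from compound 1 to compound 2, at the same kind of place, so the one measured step is the only guide. Because a 1.9-fold higher number from compound 1 to compound 2 (0.28 log units; within the scatter) was a small step, the step of a 1.9-fold higher number from compound 3 to compound 4 (0.27 log units; within the scatter) is expected to be of similar size, with the number for compound 4 a little higher than that of compound 3. Within the data shown here, the estimate for compound 4 in this assay is therefore 300 umol/kg, most likely between 150 umol/kg and 620 umol/kg; with only one such step measured, the expected range is wide.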

Compound 4, dose for half-maximal effect: 382 umol/kg
Compound 4: middle estimate off by 1.3-fold (0.10 log units), on the low side, within the range that was stated.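

In this assay, putting hydrogen in place of the methyl on the aromatic carbon of the core of compound 3 gave a 2.4-fold higher number from compound 3 to compound 4 (0.38 log units; beyond the scatter). The same change therefore moved the number in the same direction on both cores, and by a similar amount: the same change on two cores in this assay, a 1.9-fold higher number (0.28 log units; within the scatter) from compound 1 to compound 2 and a 2.4-fold higher number (0.38 log units; beyond the scatter) from compound 3 to compound 4, 1.3-fold (0.10 log units) apart, within the scatter of two such steps. Within the data shown here, only the step on the core of compound 3 lies beyond the scatter on its own, and two cores are a small sample, so this supports carrying the change between these two cores but does not show that it would behave the same way on a further core, nor does it explain why the methyl makes this difference.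

The compounds shown carry only methyl or hydrogen at this place, so it remains open how a chlorine atom, a methoxy group or a longer chain such as ethyl would read in this assay. As far as these compounds go, it also remains open whether an amine or a carboxylic acid at the same place would lower the number, raise it or leave it within the scatter of the methyl compounds.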